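Dropping one hydroxy from an allyl chalcone

The compounds below may be only part of what the source reports. "The series", "measured", "known", "first", "only" and "open" are said of these compounds alone.

Two chalcones carrying three hydroxy groups on one ring have been examined in a functional assay on aorta (Rattus norvegicus, strain Sprague-Dawley) for inhibition, with a stated time of 20 min; a lower number here means a smaller maximal response, a higher number a larger maximal response. Compound 1, `O=C(/C=C/c1cccc(Br)c1)c1c(O)cc(O)cc1O`, gives in this assay a maximal response of 99.8%. Compound 2, `C=CCc1c(O)cc(O)c(C(=O)/C=C/c2ccc(O)cc2)c1O`, which carries an allyl group and a hydroxy on its other ring, gives in this assay a value of 108%. Compound 2 thus holds the greater of the two numbers, but its gap to compound 1 lies within the usual scatter, so the two compounds cannot be told apart on this read-out.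

Compound 3, `C=CCc1c(O)ccc(C(=O)/C=C/c2ccc(O)cc2)c1O`, is the next compound and has not yet been measured. It differs from compound 2 in one place: hydrogen in place of hydroxy on an aromatic carbon. Among the measured compounds shown here, since both measured compounds reach essentially the full maximal response, and no step between them is larger than the scatter, there is no basis to expect a movement beyond the scatter from this change either. Compound 3 is therefore estimated to give in this assay a maximal response of 100%, with a range from 82% to 115%, which means an expected step of a number 8 percentage points lower from compound 2 to compound 3 (within the scatter).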

Compound 3, largest response reached (Emax), in percent of the reference or control that the assay uses: 73.4%
For compound 3 the middle estimate is 26.6 percentage points above the measured one; measured number outside the range, below it.
By their numbers in this assay, from the lowest: compound 3; then compounds 1 and 2 (each within the scatter of the next).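

In this assay the exchange of hydroxy for hydrogen brings a number 34.6 percentage points lower from compound 2 to compound 3 (beyond the scatter) and thereby shows that the maximal response is sensitive to what sits on this aromatic carbon, ortho to a large group and para to an allyl group. The earlier compounds shown here offered no step that could be read, so nothing before this pair tied the read-out to a single place in the structure; here the allyl group, the remaining hydroxy groups and the other ring all stay the same, and the loss of one hydroxy alone accompanies a shift beyond the scatter. Nothing measured here explains why this hydroxy carries such weight.

The compounds shown leave open whether the hydroxy itself is required at this carbon or whether another group would hold the response, as a methoxy group, a fluorine atom or an amine there would tell. They also leave open whether the same step would appear with a propyl chain in place of the allyl group, or with no chain at all.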